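Hydrazone substituent exchange on the shared core

The source may hold more compounds than are shown below. What is called first, only, known or untested is meant among the compounds shown, and "the series" means these compounds.

Compound 1 `Nc1nc(N/N=C/C2CCCC2)nc2c1ncn2[C@@H]1O[C@H](CO)[C@@H](O)[C@H]1O` carries a cyclopentyl group on the carbon with a double bond to nitrogen; in an assay on CHO-K1 cells for displacement of a labelled ligand from adenosine receptor A1 (Homo sapiens), read by scintillation counting, with a stated time of 60 min (on this read-out higher numbers stand for weaker inhibition and lower numbers for stronger inhibition), compound 1 gives 5.6 nM. Within the data shown here, compound 2 `CCCCc1nc(/C=N/Nc2nc(N)c3ncn([C@@H]4O[C@H](CO)[C@@H](O)[C@H]4O)c3n2)c(Cl)[nH]1` bears 2-butyl-5-chloro-1H-imidazol-4-yl on that carbon, and in this assay compound 2 gives 12 nM, the highest of the two numbers so far; the single measured step, a 2.1-fold higher number from compound 1 to compound 2 (0.33 log units; beyond the scatter), is modest yet beyond the scatter. Compound 3 `Nc1nc(N/N=C/c2ccc(-n3ccnc3)cc2)nc2c1ncn2[C@@H]1O[C@H](CO)[C@@H](O)[C@H]1O` differs from compound 2 by 4-(1H-imidazol-1-yl)phenyl in place of 2-butyl-5-chloro-1H-imidazol-4-yl on a carbon with a double bond to nitrogen. Among the measured compounds shown here, no measured step covers this exact exchange; the only related observation is that moving from cyclopentyl to an aromatic ring group, a 2.1-fold higher number from compound 1 to compound 2 (0.33 log units; beyond the scatter), raised the number modestly. Replacing one aromatic ring group by another on the same carbon is therefore expected to shift the number little, if anything slightly upward, so the expected step is a 1.3-fold higher number from compound 2 to compound 3 (0.10 log units; within the scatter). For compound 3 the estimate in this assay is 15 nM, with a range of 5 nM to 45 nM.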

Compound 3, inhibition constant: > 10000 nM
Compound 3: a limit, no number (the forecaster's own chance of this, stated with the estimate: 3%); middle value at least 660-fold (2.82 log units) away from the limit.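

In this assay compound 3 stands at a limit of the assay, not at a number: the limit of > 10000 nM in this assay, at which 1 of the 3 values shown sits. The exchange on the carbon with a double bond to nitrogen gives an at least 830-fold higher number from compound 2 to compound 3 (2.92 log units; beyond the scatter), and the comparison with the cyclopentyl group gives an at least 1700-fold higher number from compound 1 to compound 3 (3.25 log units; beyond the scatter). The earlier modest step, a 2.1-fold higher number from compound 1 to compound 2 (0.33 log units; beyond the scatter), had suggested a forgiving position, but these large steps show that the outcome depends strongly on which aromatic group sits there, since both compound 2 and compound 3 carry a five-membered aromatic ring with 2 hetero atoms.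

The compounds shown cannot separate the contribution of the phenyl ring from that of the imidazol-1-yl group on it. On these data alone, an unsubstituted phenyl, or a phenyl bearing a methoxy group or a carboxylic acid, would address that question, and how far compound 3 lies beyond its limit remains open.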